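The source may hold more compounds than are shown below. What is called first, only, known or untested is meant among the compounds shown, and "the series" means these compounds.

Measured in a physicochemical assay for lipophilicity; a lower number here means a more polar compound, a higher number a more lipophilic compound:
compound 1 `COc1cccc(CNCc2c(-c3nnc(SC(C)C)n3-c3ccccc3)n(C)c3ccccc23)c1` — 6.27
compound 2 `CC(C)Sc1nnc(-c2c(CNc3cnccn3)c3ccccc3n2C)n1-c1ccccc1` — 4.22
compound 3 `CC(C)Sc1nnc(-c2c(CNCCN3CCCC3)c3ccccc3n2C)n1-c1ccccc1` — 4.83

Compound 1 stands highest of the three in this assay, with compound 3 nearest and compound 2 furthest. Compound 4 `CC(C)Sc1nnc(-c2c(CNCC3CC3)c3ccccc3n2C)n1-c1ccccc1` is not yet measured. Against compound 1 the difference is cyclopropyl in place of 3-methoxyphenyl on a saturated chain carbon bound to an amine nitrogen. The step that bears on it most directly is a number 1.44 log units lower from compound 1 to compound 3 (beyond the scatter), where the same 3-methoxyphenyl left the same place; a number 2.05 log units lower from compound 1 to compound 2 (beyond the scatter) removed the 3-methoxybenzyl as well and was larger still. Cyclopropyl brings no hydrogen-bond acceptor, unlike the groups entering in those two steps, so a smaller drop than either is expected, though still beyond the scatter. The expected step is a number 1.07 log units lower from compound 1 to compound 4 (beyond the scatter). Compound 4 is therefore estimated at 5.2, in the range 4.7 to 5.7.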

Compound 4, partition coefficient: 5.24
Estimate against measurement, compound 4: 0.04 log units below; measured number inside the range.
By their numbers in this assay, from the lowest: compound 2; then compound 3; then compound 4; then compound 1.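

In this assay cyclopropyl, whose count shows no hydrogen-bond acceptor, still gives a number 1.03 log units lower from compound 1 to compound 4 (beyond the scatter) at this saturated chain carbon, so a large step here does not require an entering acceptor. Among the smaller substituents on the amine nitrogen, the cyclopropylmethyl compound stands clear of the others, with a number 0.41 log units higher from compound 3 to compound 4 (beyond the scatter) and a number 1.02 log units higher from compound 2 to compound 4 (beyond the scatter) in the same series. Nothing measured here gives a cause for these steps.

On these data alone, how much of the step from compound 1 belongs to the methoxy and how much to the phenyl ring stays open, and an unsubstituted phenyl at this place would separate them. A longer alkyl chain or a carboxylic acid at this place also remains unplaced.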